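The source may hold more compounds than are shown below. What is called first, only, known or untested is meant among the compounds shown, and "the series" means these compounds.

The shared core carries a phenyl-bearing ring joined through a short linker to a second six-membered ring, which in turn carries a varying group. Compound 1 `Cc1cccc(N2CCN(C(=O)CN3C(=O)CC(C)(c4ccccc4)C3=O)CC2)c1` and compound 3 `CC1(c2ccccc2)CC(=O)N(CC(=O)N2CCC(Cc3ccccc3)CC2)C1=O` are the two analogues with a number in a functional assay on the whole organism (strain CD-1) with Mus musculus as the target, in the maximal electroshock model, with a stated time of 2 h; a lower number here means that less compound is needed, a higher number that more compound is needed for the effect: compound 1 gives 300 mg/kg, and compound 3 gives 300 mg/kg, two values that lie within the usual scatter of each other. Compound 2 `COc1cccc(N2CCN(C(=O)CN3C(=O)CC(C)(c4ccccc4)C3=O)CC2)c1` stands apart on the numbers shown: in this assay compound 2 is reported as "not active" (no number reported), so no single number exists for it. Compound 4 `CC1(c2ccccc2)CC(=O)N(CC(=O)N2CCN(c3ccc(Cl)c(Cl)c3)CC2)C1=O` differs from compound 2 by a single exchange (3,4-dichlorophenyl in place of 3-methoxyphenyl on an amine nitrogen in a ring). Within the data shown here, since no measured pair tells how this exchange changes the outcome in this assay, the size and direction of the step cannot be read from data; the two numbered compounds suggest that active members sit around the same dose, while compound 2 shows that a change at this ring nitrogen can also remove activity. Compound 4 is expected to give about 300 mg/kg, with a range from 100 mg/kg to 1000 mg/kg.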

Compound 4, minimum effective dose: 300 mg/kg
For compound 4 middle estimate and measured number coincide at the digits printed, within the range that was stated.
By their numbers in this assay, from the lowest: compounds 1, 3 and 4 (each within the scatter of the next).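

Compound 4 shows that this amine nitrogen in a ring can carry 3,4-dichlorophenyl and still give a numbered dose in this assay. There is no change at the digits printed from compound 1 to compound 4 (within the scatter) when 3,4-dichlorophenyl takes the place of 3-methylphenyl, so these two groups cannot be told apart here, while compound 2, with 3-methoxyphenyl at the same place, has no number and its step to compound 4 cannot be read. Nothing shown accounts for why the 3-methoxyphenyl compound alone is reported as not active.

Still open, as far as these compounds go, is how a plain phenyl or a pyridine ring on this nitrogen would behave in this assay. From the compounds shown here alone, it is also open whether a carboxylic acid or an amine on the phenyl ring would give a numbered dose, or no number, as with compound 2.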